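The source may report more compounds than this note shows. Statements on the series, on what has been measured and on what is new or still open speak of the compounds shown alone.

Working notes on the series.

Compound 1 `Cc1cccc2c1CC/C2=C\C(=O)NC1CC1` gives 40 mg/kg in a functional assay on the whole organism with Mus musculus as the target; a lower number here means that less compound is needed, a higher number that more compound is needed for the effect. Compound 2 `Cc1cccc2c1CC/C2=C\C(N)=O` reaches only a limit in this assay, > 100 mg/kg. The step of an at least 2.5-fold higher number from compound 1 to compound 2 (0.39 log units; beyond the scatter) follows the change (hydrogen in place of cyclopropyl on an amide-type nitrogen), and sits at the limit of > 100 mg/kg in this assay, at which 1 of the 3 values shown sits. Compound 3 `O=C(/C=C1\CCc2c(F)ccc(F)c21)NC1CC1` gives 59 mg/kg in this assay, within the scatter of compound 1; the difference between the cores of compound 1 and compound 3 is not broken down here. Compound 4 `NC(=O)/C=C1\CCc2c(F)ccc(F)c21` is the same change made on compound 3: hydrogen in place of cyclopropyl on an amide-type nitrogen. The same loss is expected here as seen in the step of an at least 2.5-fold higher number from compound 1 to compound 2 (0.39 log units; beyond the scatter). Compound 4 is expected to give about 160 mg/kg in this assay, between 60 mg/kg and 450 mg/kg, an expected step of a 2.7-fold higher number from compound 3 to compound 4 (0.43 log units; beyond the scatter), most likely reported only as a limit.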

Compound 4, dose for half-maximal effect: 56 mg/kg
Beside the measured number, compound 4's estimate is 2.9-fold (0.46 log units) above it, outside the stated range (below it).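

On the core of compound 3, hydrogen in place of cyclopropyl on an amide-type nitrogen gives a 1.1-fold lower number from compound 3 to compound 4 (0.02 log units; within the scatter) in this assay. Compound 2 is reported only as a limit (> 100 mg/kg). Set beside the earlier step, the new one does not show that the change acts differently on the two cores: the same change on two cores in this assay, an at least 2.5-fold higher number (0.39 log units; beyond the scatter) from compound 1 to compound 2 and a 1.1-fold lower number (0.02 log units; within the scatter) from compound 3 to compound 4; the limit leaves it open whether they differ.

The compounds shown leave open how a methyl or a longer chain on the amide nitrogen would read on either core. They also leave open how a core carrying a single fluorine would compare with the cores of compound 1 and compound 3.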